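The compounds below may be only part of what the source reports. "The series", "measured", "known", "first", "only" and "open" are said of these compounds alone.

Among the compounds with values here, compound 2 `Nc1scc(CN2CCN(c3ccc(C(F)(F)F)cc3)CC2)c1C(=O)c1ccc(Cl)cc1` is one of two compounds measured in an assay on CHO cells for displacement of a labelled ligand from adenosine receptor A1 (Homo sapiens); a higher number here means weaker binding, a lower number tighter binding. In this assay compound 2 gives 1.9 nM. Its nearest companion is compound 1 `CN1CCN(Cc2csc(N)c2C(=O)c2ccc(Cl)cc2)CC1`, which in this assay gives 1.7 nM; the two values lie within the scatter of each other, so neither can be placed above the other.

The step from compound 2 to compound 3 `Nc1scc(CN2CCN(c3ccccn3)CC2)c1C(=O)c1ccc(Cl)cc1` is pyridin-2-yl in place of 4-(trifluoromethyl)phenyl on an amine nitrogen in a ring. Within the data shown here, only one measured step bears on it: the change from methyl to 4-(trifluoromethyl)phenyl on the same ring nitrogen, which gave a 1.1-fold higher number from compound 1 to compound 2 (0.05 log units; within the scatter). That step shows that the group on this ring nitrogen, whether methyl or a six-membered aromatic ring with a trifluoromethyl group, left the number in this assay essentially where it was. Nothing measured distinguishes a six-membered aromatic ring with one nitrogen from one of carbon only at this position, so the expectation is for no step beyond the scatter, with the estimated change being a 1.3-fold higher number from compound 2 to compound 3 (0.12 log units; within the scatter). For compound 3 the number expected in this assay is therefore 2.5 nM, within a range from 0.8 nM to 8 nM.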

Compound 3, dissociation constant: 1.7 nM
Estimate against measurement, compound 3: 1.5-fold (0.17 log units) above, and the stated range covers the measured number.
By their numbers in this assay, from the lowest: compounds 1, 3 and 2 (each within the scatter of the next).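

In this assay, pyridin-2-yl on the amine nitrogen in the ring gave a 1.1-fold lower number from compound 2 to compound 3 (0.05 log units; within the scatter) when it replaced 4-(trifluoromethyl)phenyl, and no change at the digits printed from compound 1 to compound 3 (within the scatter) when it replaced methyl. The earlier step had compared only methyl with a six-membered aromatic ring of carbon only, whereas this result adds a six-membered aromatic ring with a hetero atom and a hydrogen-bond acceptor, and the number still shows no step beyond the scatter. Across these three groups, then, neither the loss of the trifluoromethyl group nor the entry of the ring nitrogen separates the compounds, and nothing available explains why the number holds at this position.

From the compounds shown here alone, whether a longer alkyl chain, a carboxylic acid or an amide on this ring nitrogen would also leave the number in place remains open. Also open, going by these compounds, is what a change elsewhere on the shared core would do to the number, as all three compounds carry that core unchanged.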